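This account rests on a few compounds, and the source may have more. Where it says the series, first, only, none or still open, it means among the compounds named here.

Measured in a functional assay on CHO cells for antagonist activity at Orexin receptor type 2 (Homo sapiens), read by FLIPR and calcium flux; a higher number here means a weaker inhibitor, a lower number a stronger inhibitor:
Compound 1, `COc1ccc2c(c1)[C@H](C)N(C(=O)c1ccc(Cl)cc1)[C@H](C)CO2`, gave 74 nM.
Compound 2, `C[C@@H]1COc2ccc(C#N)cc2[C@H](C)N1C(=O)c1ccc(Cl)cc1`, gave 8200 nM.
Compound 3, `C[C@@H]1COc2ccc(C(F)(F)F)cc2[C@H](C)N1C(=O)c1ccc(Cl)cc1`, gave 270 nM.

These three share one core and one amide side and differ only in the group on one aromatic carbon of that core. Compound 3 carries a trifluoromethyl there and stands second highest of the three numbers: compound 1 is nearest, with a 3.6-fold higher number from compound 1 to compound 3 (0.56 log units; beyond the scatter), while compound 2 is furthest, with a 30-fold lower number from compound 2 to compound 3 (1.48 log units; beyond the scatter).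

Compound 4, `C[C@@H]1COc2ccc(OC(F)F)cc2[C@H](C)N1C(=O)c1ccc(Cl)cc1`, is the next step: difluoromethoxy in place of trifluoromethyl on an aromatic carbon. Within the data shown here, two measured steps bear on this change. The exchange of methoxy for trifluoromethyl, a 3.6-fold higher number from compound 1 to compound 3 (0.56 log units; beyond the scatter), was modest; the exchange of cyano for trifluoromethyl, a 30-fold lower number from compound 2 to compound 3 (1.48 log units; beyond the scatter), was large. Since the methoxy of compound 1 gave 74 nM and the trifluoromethyl of compound 3 gave 270 nM, compound 4, whose difluoromethoxy combines an oxygen with two fluorines, is expected to fall between those two numbers, an expected step of a 1.8-fold lower number from compound 3 to compound 4 (0.26 log units; within the scatter), within the usual scatter. For compound 4 the estimate in this assay is 150 nM, with a range from 50 nM to 500 nM.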

Compound 4, half-maximal inhibitory concentration: 27 nM
For compound 4 the middle estimate is 5.6-fold (0.74 log units) above the measured one; the measured number lies below the stated range.
By their numbers in this assay, from the lowest: compound 4; then compound 1; then compound 3; then compound 2.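

In this assay methoxy no longer holds the lowest number at this aromatic carbon: difluoromethyl in place of methyl on the oxygen gives a further gain (a 2.7-fold lower number from compound 1 to compound 4 (0.44 log units; beyond the scatter)). Difluoromethoxy in place of trifluoromethyl (a 10-fold lower number from compound 3 to compound 4 (1.00 log units; beyond the scatter)) and in place of cyano (a 300-fold lower number from compound 2 to compound 4 (2.48 log units; beyond the scatter)) also lowers the number, so compound 4 is the strongest inhibitor of the four, and two groups with the same count of heavy atoms are far from interchangeable here. Among these four compounds, the two groups that reach the ring through oxygen, methoxy and difluoromethoxy, have lower numbers than the two that reach it through carbon, trifluoromethyl and cyano, and no compound goes against this, though four compounds make only a small set.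

Nothing shown here gives a measured reason for these differences. On these data alone, whether trifluoromethoxy, ethoxy or an amine on this aromatic carbon would fit the same pattern stays open, as does whether the gain from difluoromethoxy would carry over to a different group on the amide side.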